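A few compounds are considered here, and "the series" means these few. Any claim that something is new, unique, unknown or untested is made for them only; others in the source may bear on it.

The study concerns a shared core carrying two amine substituents, tested for how strongly each member holds back the growth of cultured cells in a functional assay on DU-145 cells (Homo sapiens) for cytotoxicity, read by MTT assay, with a stated time of 2 days, tested at 10 uM; on this read-out higher numbers stand for more inhibition at the one concentration tested (going by the name of the read-out) and lower numbers for less inhibition. Within the data shown here, compound 1 `COc1ccc(Nc2nc(NCc3ccco3)c3cc(F)ccc3n2)cc1` stands lowest of the three numbers measured so far: in this assay compound 1 gives 55.4%. Compound 2 `Clc1cccc(N2CCN(CCCNc3nc(NCc4ccco4)c4ccccc4n3)CC2)c1Cl` gives 93.2% in this assay, a number beyond the scatter above compound 1. Compound 3 `Cc1cccc(N2CCN(CCCNc3nc(NCc4ccco4)c4cc(F)ccc4n3)CC2)c1C` gives 95.9% in this assay, also beyond the scatter above compound 1. Both of these carry a differently built group on the nitrogen where compound 1 bears its 4-methoxyphenyl.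

Compound 4 `CCN(CC)CCNc1nc(NCc2ccco2)c2cc(F)ccc2n1` has not yet been measured. It differs from compound 1 in one place: 2-(diethylamino)ethyl in place of 4-methoxyphenyl on a nitrogen on an aromatic ring. Among the measured compounds shown here, no pair of measured compounds differs in just this way, so the size of the step is uncertain. A moderate rise is nonetheless expected, because compound 2 at 93.2% and compound 3 at 95.9% both score far above compound 1 after a change at this same nitrogen. The expected step is a number 9.6 percentage points higher from compound 1 to compound 4 (within the scatter). For compound 4 the estimate in this assay is 65%, expected to fall between 42% and 85%.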

Compound 4, a percentage reported as inhibition, at one concentration (the size of the read-out at that concentration, not a potency): 26.6%
Compound 4: middle estimate off by 38.4 percentage points, on the high side; measured number outside the range, below it.
By their numbers in this assay, from the lowest: compound 4; then compound 1; then compounds 2 and 3 (each within the scatter of the next).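

Among these compounds, this is the first change at this position that can be read on its own, with the rest of the molecule left the same. In this assay, putting 2-(diethylamino)ethyl in place of 4-methoxyphenyl on this nitrogen gives a number 28.8 percentage points lower from compound 1 to compound 4 (beyond the scatter), so this single swap, from a group with an aromatic ring to an open chain with no ring, is enough to lower the number beyond the scatter. Nothing available explains why the number falls.

The compounds shown do not separate the loss of the aromatic ring from the arrival of the diethylamino group. An unsubstituted phenyl, a 4-methoxybenzyl or a plain hexyl chain on the same nitrogen could help tell these two apart, and a longer chain ending in diethylamino could show whether chain length matters.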